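Piperidine nitrogen substituent series at the incretin receptor

A few compounds are considered here, and "the series" means these few. Any claim that something is new, unique, unknown or untested is made for them only; others in the source may bear on it.

Measured so far:
compound 1 `CC(C)COC(=O)N1CCC(Oc2ncnc3c2CCN3c2ccc(S(C)(=O)=O)cc2F)CC1`: 25.1 nM
compound 2 `CCSC(=O)N1CCC(Oc2ncnc3c2CCN3c2ccc(S(C)(=O)=O)cc2F)CC1`: 31.6 nM

In a functional assay on CHO-K1 cells for agonist activity at Glucose-dependent insulinotropic receptor (Homo sapiens), read by a luciferase reporter, with a stated time of 5 h (a higher number here means that more compound is needed for the effect, a lower number that less compound is needed), compound 1 gives 25.1 nM and compound 2 gives 31.6 nM; the change a 1.3-fold higher number from compound 1 to compound 2 (0.10 log units; within the scatter) lies within the scatter. Compound 2 therefore holds the higher of the two numbers, yet it cannot be separated from compound 1 on the data at hand.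

Compound 3 `CN(C)S(=O)(=O)N1CCC(Oc2ncnc3c2CCN3c2ccc(S(C)(=O)=O)cc2F)CC1` has not been measured. It differs from compound 2 by dimethylsulfamoyl in place of (ethylsulfanyl)carbonyl on an amine nitrogen in a ring. Within the data shown here, the one step measured so far, a 1.3-fold higher number from compound 1 to compound 2 (0.10 log units; within the scatter), exchanges only the group attached to the carbonyl carbon and leaves the carbonyl itself in place; in compound 3 the carbonyl carbon is gone and a dimethylsulfamoyl group sits on the ring nitrogen instead. Among the measured compounds shown here, no measured step covers a change of this kind, so the expectation rests on the observation that the one change at this position so far, a 1.3-fold higher number from compound 1 to compound 2 (0.10 log units; within the scatter), stayed within the scatter.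

For the measured compounds named here, for compound 3 the expected step of a 1.3-fold higher number from compound 2 to compound 3 (0.10 log units; within the scatter) is small, with a wide range because no close precedent exists. The estimate for compound 3 in this assay is 40 nM, between 12 nM and 130 nM.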

Compound 3, half-maximal effective concentration: 398 nM
Compound 3: middle estimate off by 10-fold (1.00 log units), on the low side; the measured number lies above the stated range.
By their numbers in this assay, from the lowest: compounds 1 and 2 (each within the scatter of the next); then compound 3.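

In this assay, this position on the ring nitrogen proves sensitive to the type of group attached: dimethylsulfamoyl in place of (ethylsulfanyl)carbonyl gives a 13-fold higher number from compound 2 to compound 3 (1.10 log units; beyond the scatter) and dimethylsulfamoyl in place of isobutoxycarbonyl gives a 16-fold higher number from compound 1 to compound 3 (1.20 log units; beyond the scatter) in this series. The earlier step, a 1.3-fold higher number from compound 1 to compound 2 (0.10 log units; within the scatter), changed only the group on the carbonyl carbon and showed no such sensitivity, so among these three compounds the large steps appear only where the carbonyl leaves the ring nitrogen. Nothing on hand accounts for the size of these steps.

Each large step exchanges the carbonyl link and the group at its end together, so the compounds shown leave open which of the two changes carries the loss. A dimethylcarbamoyl group on the same nitrogen would keep the carbonyl and the dimethylamino end, and a methanesulfonyl group would keep the sulfonyl link without the amine, but the compounds shown do not tell how either would read.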